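A few compounds are considered here, and "the series" means these few. Any claim that something is new, unique, unknown or untested is made for them only; others in the source may bear on it.

Compound 1 `COc1ccc(/C=C2\CCC/C(=C\c3cccc(OC)c3OC)C2=O)cc1` and compound 3 `COc1ccc(/C=C2\CCC/C(=C\c3ccc(OC)c(OC)c3)C2=O)cc1` are built from the same atoms joined differently; the difference between the two cores is not broken down here. In an ADME assay on NHDF cells (Homo sapiens) for cytotoxicity, read by MTT assay, with a stated time of 72 h (on this read-out lower numbers stand for stronger inhibition and higher numbers for weaker inhibition), compound 1 gives 43500 nM, and compound 3 gives 30900 nM, two values that lie within the usual scatter of each other. Compound 2 `COc1cccc(/C=C2\CCC/C(=C\c3cccc(O)c3)C2=O)c1OC` carries 3-hydroxyphenyl in place of 4-methoxyphenyl on a double-bonded chain carbon bound to a double-bonded ring carbon. In this assay compound 2 gives 19300 nM, a step of a 2.3-fold lower number from compound 1 to compound 2 (0.35 log units; beyond the scatter). Compound 4 `COc1ccc(/C=C2\CCC/C(=C\c3cccc(O)c3)C2=O)cc1OC` relates to compound 3 through the same change, (3-hydroxyphenyl in place of 4-methoxyphenyl on a double-bonded chain carbon bound to a double-bonded ring carbon). Since that change has once given a 2.3-fold lower number from compound 1 to compound 2 (0.35 log units; beyond the scatter) from a starting value that compound 3 nearly matches in 30900 nM, a step of about the same size is expected here. For compound 4 in this assay the estimate is 14000 nM, between 7000 nM and 28000 nM, which means an expected step of a 2.2-fold lower number from compound 3 to compound 4 (0.34 log units; beyond the scatter).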

Compound 4, half-maximal inhibitory concentration: 6800 nM
Beside the measured number, compound 4's estimate is 2.1-fold (0.31 log units) above it; the whole stated range lies above it.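

In this assay, 3-hydroxyphenyl in place of 4-methoxyphenyl gives a 4.5-fold lower number from compound 3 to compound 4 (0.66 log units; beyond the scatter), a step in the same direction as the earlier one and not distinguishable from it in size: the same change on two cores in this assay, a 2.3-fold lower number (0.35 log units; beyond the scatter) from compound 1 to compound 2 and a 4.5-fold lower number (0.66 log units; beyond the scatter) from compound 3 to compound 4, 2.0-fold (0.30 log units) apart, within the scatter of two such steps. On these two cores, then, the change carries over, lowering the number on both. That rests on just two pairs, however, and it does not show that the change would act alike on any other core, nor why the number falls.

The compounds shown leave open whether the step depends on the hydroxy group itself. An amine or a carboxylic acid in its place on the phenyl ring might give a step of quite another size.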